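A few compounds are considered here, and "the series" means these few. Any claim that something is new, unique, unknown or untested is made for them only; others in the source may bear on it.

In an assay for inhibition of Indoleamine 2,3-dioxygenase 1 (Homo sapiens), read by fluorescence, with a stated time of 24 h (on this read-out lower numbers stand for stronger inhibition and higher numbers for weaker inhibition), the measured compounds are: compound 1 `NS(=O)(=O)CC(=O)NCCSc1nonc1/C(=N/O)Nc1cccc(C(F)F)c1` with 17 nM; compound 2 `COc1nonc1/C(=N/O)Nc1ccc(F)c(Br)c1` with 39 nM; compound 3 `C[C@@H](CSc1nonc1/C(=N/O)Nc1ccc(F)c(Br)c1)NC(=O)CS(N)(=O)=O` with 19 nM.

Compound 1 holds the lowest of the three numbers in this assay. Compound 3 lies within the usual scatter of it, so no order between those two can be read; compound 2 stands beyond the scatter with a higher number.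

The step to compound 4 `NS(=O)(=O)CC(=O)NCCSc1nonc1/C(=N/O)Nc1cccc(Br)c1` is a single change: bromo in place of difluoromethyl on an aromatic carbon. Within the data shown here, no measured pair shows this exact change, but compounds 2 and 3 both carry a bromo on the aniline ring and sit near compound 1 in this assay. A step no larger than the scatter, in either direction, is therefore expected. The expected step of a 1.2-fold higher number from compound 1 to compound 4 (0.07 log units; within the scatter) is accordingly small. Compound 4 is estimated at 20 nM, with a range from 8 nM to 50 nM.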

Compound 4, half-maximal inhibitory concentration: 8.1 nM
For compound 4 the middle estimate is 2.5-fold (0.39 log units) above the measured one; low and high end bracket the measured number.
By their numbers in this assay, from the lowest: compound 4; then compounds 1 and 3 (each within the scatter of the next); then compound 2.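

In this assay, among these compounds, bromo in place of difluoromethyl on the aromatic carbon gives a 2.1-fold lower number from compound 1 to compound 4 (0.32 log units; beyond the scatter) and provides the first comparison in which only this group differs. With the rest of compound 1 unchanged, this position accepts the smaller bromo group, and the step is modest. Nothing measured here accounts for the difference. As far as these compounds go, how chloro, trifluoromethyl or a nitrile would compare at this position remains open. So does whether the same change would give a similar step on a compound with a different chain on the sulfur.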